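Carbonyl substituent swap on the shared core

A few compounds are considered here, and "the series" means these few. Any claim that something is new, unique, unknown or untested is made for them only; others in the source may bear on it.

Compound 3 `COc1ncc(-c2ccc3ncc(C(=O)N4CCC(O)CC4)n3c2)cc1NS(=O)(=O)c1ccc(F)cc1F` gives 630 nM in a functional assay on MDA-MB-231 cells (Homo sapiens) for antiproliferative activity, read by sulforhodamine B assay, with a stated time of 72 h (on this read-out lower numbers stand for stronger inhibition and higher numbers for weaker inhibition), the highest of the three numbers; compound 2 `COc1ncc(-c2ccc3ncc(C(=O)O)n3c2)cc1NS(=O)(=O)c1ccc(F)cc1F` gives 370 nM, and compound 1 `CCOC(=O)c1cnc2ccc(-c3cnc(OC)c(NS(=O)(=O)c4ccc(F)cc4F)c3)cn12` gives 120 nM. The step of a 1.7-fold higher number from compound 2 to compound 3 (0.23 log units; within the scatter) is within the scatter, whereas a 5.3-fold higher number from compound 1 to compound 3 (0.72 log units; beyond the scatter) and a 3.1-fold higher number from compound 1 to compound 2 (0.49 log units; beyond the scatter) lie beyond it. Compound 4 `COc1ncc(-c2ccc3ncc(C(=O)NCc4ccncc4)n3c2)cc1NS(=O)(=O)c1ccc(F)cc1F` differs from compound 3 by ((pyridin-4-yl)methyl)amino in place of 4-hydroxypiperidin-1-yl on a carbonyl carbon. All measured steps alter the group on the carbonyl carbon; the closest in kind, a 1.7-fold higher number from compound 2 to compound 3 (0.23 log units; within the scatter), is small, and the largest, a 5.3-fold higher number from compound 1 to compound 3 (0.72 log units; beyond the scatter), is only modest. Among the measured compounds shown here, no step between two nitrogen-linked groups on that carbonyl has been measured. A change in this assay not beyond the scatter is therefore expected, a 1.3-fold lower number from compound 3 to compound 4 (0.10 log units; within the scatter). Compound 4 is estimated at 500 nM, range 200 nM to 1500 nM.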

Compound 4, half-maximal inhibitory concentration: 420 nM
Beside the measured number, compound 4's estimate is 1.2-fold (0.08 log units) above it, and the stated range covers the measured number.
By their numbers in this assay, from the lowest: compound 1; then compounds 2, 4 and 3 (each within the scatter of the next).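

In this assay, among the compounds shown here, the first step between two nitrogen-linked groups on the carbonyl carbon (a 1.5-fold lower number from compound 3 to compound 4 (0.18 log units; within the scatter)) stays within the scatter, so ((pyridin-4-yl)methyl)amino and 4-hydroxypiperidin-1-yl are not told apart. Hydroxy on that carbon is not told apart from ((pyridin-4-yl)methyl)amino either (a 1.1-fold higher number from compound 2 to compound 4 (0.06 log units; within the scatter)), while ethoxy remains separate (a 3.5-fold higher number from compound 1 to compound 4 (0.54 log units; beyond the scatter)), making compound 1 the only one of the four set apart from the rest. No data given here explain these steps.

Open, going by these compounds, is whether a methyl ester, a primary amide or a longer chain before the pyridine ring would match compound 1 on the carbonyl carbon.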